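The source may hold more compounds than are shown below. What is called first, only, known or untested is meant among the compounds shown, and "the series" means these compounds.

The measured compounds:

compound 1, `CC(=O)NC1=CS(=O)(=O)O[C@@]12[C@@H](CO[Si](C)(C)C(C)(C)C)O[C@@H](n1cc(C)c(=O)n(C)c1=O)[C@@H]2O[Si](C)(C)C(C)(C)C` — >= 80000 nM
compound 2, `Cc1cn([C@@H]2O[C@H](CO[Si](C)(C)C(C)(C)C)[C@@]3(OS(=O)(=O)C=C3NCCC(=O)OCc3ccccc3)[C@H]2O[Si](C)(C)C(C)(C)C)c(=O)n(C)c1=O` — >= 400000 nM

In a functional assay on HEL cells (Homo sapiens) for cytotoxicity, read by microscopy (a higher number here means that more compound is tolerated, a lower number that less compound is tolerated), compound 2 gives >= 400000 nM, and this is a limit of the assay rather than a number. Compound 1, `CC(=O)NC1=CS(=O)(=O)O[C@@]12[C@@H](CO[Si](C)(C)C(C)(C)C)O[C@@H](n1cc(C)c(=O)n(C)c1=O)[C@@H]2O[Si](C)(C)C(C)(C)C`, gives >= 80000 nM in this assay, again a limit. The step that the two limits leave unreadable from compound 1 to compound 2 therefore cannot be read, since both values rest on limits, as the limit of >= 400000 nM in this assay, at which 1 of the 2 values shown sits, and the limit of >= 80000 nM in this assay, at which 1 of the 2 values shown sits, show. Compound 3, `Cc1cn([C@@H]2O[C@H](CO[Si](C)(C)C(C)(C)C)[C@@]3(OS(=O)(=O)C=C3NCC(=O)C(N)=O)[C@H]2O[Si](C)(C)C(C)(C)C)c(=O)n(C)c1=O`, differs from compound 2 by carbamoylcarbonyl in place of (benzyloxycarbonyl)methyl on a saturated chain carbon bound to an amine nitrogen. Within the data shown here, no measured step bears on this change in a readable way: the one step in hand is unreadable. With both measured compounds tolerated up to their limits, compound 3 is expected to be tolerated as well, so the step of an at least 2.0-fold lower number from compound 2 to compound 3 (0.30 log units; that floor lies within the scatter) is estimated to be none beyond the scatter, with a limit the likely outcome. Compound 3 is thus estimated at 200000 nM, in the range 60000 nM to 400000 nM.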

Compound 3, minimum cytotoxic concentration: >= 16000 nM
Compound 3 was reported as a limit (the forecaster's own chance of this, stated with the estimate: 80%); the middle value lies beyond the limit too.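

In this assay compound 3 gives >= 16000 nM, which is a limit of the assay. Among these compounds, compound 1, compound 2 and compound 3 all rest on limits, and no step among them can be read. From the compounds shown here alone, how much of each compound is tolerated, and whether the group on the amine nitrogen changes that, stays open.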